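Adding a 3-iodobenzyl group to compound 2: an expectation

The compounds below may be only part of what the source reports. "The series", "measured", "known", "first", "only" and "open" are said of these compounds alone.

Measured so far:
compound 1, `CCCCC#Cc1nc(NCc2cccc(Cl)c2)c2ncn([C@@H]3SC[C@@H](O)[C@H]3O)c2n1`, 24 nM;
compound 2, `CCCCC#Cc1nc(N)c2ncn([C@@H]3OC[C@@H](O)[C@H]3O)c2n1`, 138 nM;
compound 3, `CCCCC#Cc1nc2c(N)ncnc2n1[C@@H]1OC[C@@H](O)[C@H]1O`, 31.7 nM.

In an assay on CHO cells for displacement of a labelled ligand from adenosine receptor A3 (Homo sapiens), with a stated time of 60 min (a lower number here means a stronger inhibitor, a higher number a weaker inhibitor), compound 2 shows the highest number of the three; compound 3 stands nearer to it, compound 1 furthest, and both gaps lie beyond the scatter. Compound 4, `CCCCC#Cc1nc(NCc2cccc(I)c2)c2ncn([C@@H]3OC[C@@H](O)[C@H]3O)c2n1`, has not yet been measured. It differs from compound 2 by 3-iodobenzyl in place of hydrogen on a nitrogen on an aromatic ring. Among the measured compounds shown here, no single-change step between measured compounds exists here, so the size of this step is open. Compound 1 differs from compound 2 in several places but carries a benzyl group of the same kind, and in this assay compound 1 gives 24 nM. On that showing compound 4 is expected to give a clearly lower number, a step of a 9.2-fold lower number from compound 2 to compound 4 (0.96 log units; beyond the scatter). The estimate for compound 4 is therefore 15 nM, expected within 4 nM to 50 nM.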

Compound 4, inhibition constant: 220 nM
Compound 4: the middle estimate sits 15-fold (1.17 log units) below what was measured; measured number above the stated range.
By their numbers in this assay, from the lowest: compounds 1 and 3 (each within the scatter of the next); then compounds 2 and 4 (each within the scatter of the next).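

In this assay, among the compounds shown here, the first single-change step in this set replaces hydrogen with 3-iodobenzyl on the nitrogen and reads a 1.6-fold higher number from compound 2 to compound 4 (0.20 log units; within the scatter) for this change. On this core, then, the amino nitrogen carries the 3-iodobenzyl group with no shift that can be told from the scatter. No measurement bears on why this is so.

Going by these compounds, whether a methyl or an unsubstituted benzyl group on this nitrogen would behave the same stays open. So does whether another substituent in place of the iodine, such as a methoxy group, would move the number beyond the scatter.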